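Carboxy Terminus on the Hexylsulfanyl Chain of Compound 2

The source may report more compounds than this note shows. Statements on the series, on what has been measured and on what is new or still open speak of the compounds shown alone.

Compound 1 `CCCCCC(=O)Nc1cc(-c2ccccc2)c(-c2ccccc2)nn1` and compound 2 `CCCCCCSc1cc(-c2ccccc2)c(-c2ccccc2)nn1` share one core and differ at a single aromatic carbon. In an assay on microsomes from liver for inhibition of sterol O-acyltransferase 1 (Rattus norvegicus) (a lower number here means a stronger inhibitor, a higher number a weaker inhibitor), compound 1 gives > 300000 nM, which is a limit of the assay, not a number. In this assay, within the data shown here, compound 2 gives 62000 nM, the only number among the values shown. Among the measured compounds shown here, the sole measured step, an at least 4.8-fold lower number from compound 1 to compound 2 (0.68 log units; beyond the scatter), changes the group at the ring anchor, not the chain end. Compound 3 `O=C(O)CCCCCCSc1cc(-c2ccccc2)c(-c2ccccc2)nn1` carries carboxy in place of hydrogen on a saturated chain carbon, six bonds along the chain from a sulfur. For the measured compounds named here, no measured step alters a chain terminus, so the expected step of a 2.4-fold higher number from compound 2 to compound 3 (0.38 log units; beyond the scatter) is a weak extrapolation. Compound 3 is estimated at 150000 nM, between 40000 nM and 300000 nM.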

Compound 3, half-maximal inhibitory concentration: > 300000 nM
Compound 3: no number, only a limit; the forecaster's own chance of this, stated with the estimate: 40%; at least 2.0-fold (0.30 log units) between middle value and limit.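

In this assay, the far end of the chain proves to be a position where a change registers, which the earlier step at the ring anchor could not show: carboxy in place of hydrogen on a saturated chain carbon, six bonds along the chain from a sulfur, gives an at least 4.8-fold higher number from compound 2 to compound 3 (0.68 log units; beyond the scatter). Only a lower bound on this step can be read, because compound 3 gives a limit of the assay and not a number: the limit of > 300000 nM in this assay, at which 2 of the 3 values shown sit.

On these data alone, whether an amine or a methyl ester at this chain end would stay closer to compound 2 remains open. So does the effect of a longer chain or a shorter chain carrying the same carboxy group.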